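Swapping the Ester Cap for a Cyclohexyl Ring

The compounds below may be only part of what the source reports. "The series", "measured", "known", "first", "only" and "open" are said of these compounds alone.

Measured compounds:
compound 1 `CC(C)(C)OC(=O)CN1CCc2c(sc(NC(=O)Nc3ccc(Cl)cc3)c2C(N)=O)C1` — > 25000 nM
compound 2 `CC[N+]1(C)CCc2c(sc(NC(=O)Nc3ccc(Cl)cc3)c2C(N)=O)C1` — 1960 nM
compound 3 `CCN1CCc2c(sc(NC(=O)Nc3ccc(Cl)cc3)c2C(=O)NCCO)C1` — 9400 nM

In a functional assay (strain AB) with Danio rerio as the target, read by microscopy, with a stated time of 1 h (a higher number here means that more compound is needed for the effect, a lower number that less compound is needed), compound 1 gives only a limit, > 25000 nM, not a measured number (the limit of > 25000 nM in this assay, at which 1 of the 3 values shown sits). Compound 2 gives 1960 nM in this assay, and compound 3 gives 9400 nM. Compound 4 `NC(=O)c1c(NC(=O)Nc2ccc(Cl)cc2)sc2c1CCN(CC1CCCCC1)C2` differs from compound 1 in a single place: cyclohexyl in place of tert-butoxycarbonyl on a saturated chain carbon bound to an amine nitrogen in a ring. Among the measured compounds shown here, no measured pair shows this exact change, so its size can only be guessed from the three values above, where the two compounds that do give numbers sit well inside the measurable range. The step from compound 1 to compound 4 is expected to be a gain in potency, an at least 10-fold lower number from compound 1 to compound 4 (1.00 log units; beyond the scatter). Compound 4 is estimated at 2500 nM, with a range from 500 nM to 12000 nM.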

Compound 4, half-maximal effective concentration: 1890 nM
The estimate for compound 4 lay 1.3-fold (0.12 log units) above the measured number, within the range that was stated.
By their numbers in this assay, from the lowest: compounds 4 and 2 (each within the scatter of the next); then compound 3. At a limit, above all of these: compound 1.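

In this assay, the group on a saturated chain carbon bound to an amine nitrogen in a ring clearly matters: cyclohexyl in place of tert-butoxycarbonyl gives an at least 13-fold lower number from compound 1 to compound 4 (1.12 log units; beyond the scatter). The entering cyclohexyl carries no hydrogen-bond acceptors, yet compound 4 still gives a measured value. Compound 1 gives only a limit, so the full size of this step stays unknown: the limit of > 25000 nM in this assay, at which 1 of the 4 values shown sits.

From the compounds shown here alone, it remains open whether the step comes from gaining cyclohexyl or from losing tert-butoxycarbonyl. A phenyl ring or a carboxylic acid at the same place could help separate the two.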